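Cutting compound 2's ether down to methoxy

The compounds below may be only part of what the source reports. "The series", "measured", "known", "first", "only" and "open" are said of these compounds alone.

Among the compounds with values here, in a functional assay on PC-12 cells (Rattus norvegicus) for inhibition, read by sulforhodamine B assay (on this read-out higher numbers stand for weaker inhibition and lower numbers for stronger inhibition), compound 2 `O=C1NC(=O)C(Cc2ccc(OCC3CCCC3)cc2)S1` gives 25000 nM and stands at the weak end of the three numbers so far. Compound 3 `O=C1NC(=O)/C(=C/c2ccc(OCC3CCC3)cc2)S1` gives 13000 nM as a value within the scatter of compound 2, so the two stand level. Compound 1 `Cc1c(C)c2c(c(C)c1O)CCC(C)(COc1ccc(/C=C3/SC(=O)NC3=O)cc1)O2` gives 5000 nM as a number lower than that of compound 2, and this gap lies beyond the scatter.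

Compound 4 `COc1ccc(CC2SC(=O)NC2=O)cc1` has not yet been measured. It departs from compound 2 by hydrogen in place of cyclopentyl on a saturated chain carbon bound to an oxygen on an aromatic ring in a single place: hydrogen in place of cyclopentyl on a saturated chain carbon bound to an oxygen on an aromatic ring, so cyclopentylmethoxy becomes methoxy. Within the data shown here, no measured pair shows this change alone, which leaves the expectation loose. A small move toward weaker inhibition is expected, an estimated 1.6-fold higher number from compound 2 to compound 4 (0.20 log units; within the scatter) in this assay that probably stays within the scatter. For compound 4 the estimated value is 40000 nM with a wide expected range (15000 nM to 100000 nM).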

Compound 4, half-maximal inhibitory concentration: > 100000 nM
Compound 4 gave a limit, no number; the forecaster's own chance of this, stated with the estimate: 25%; middle value at least 2.5-fold (0.39 log units) away from the limit.
By their numbers in this assay, from the lowest: compound 1; then compounds 3 and 2 (each within the scatter of the next). At a limit, above all of these: compound 4.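

Going from cyclopentylmethoxy to methoxy gives an at least 4.0-fold higher number from compound 2 to compound 4 (0.60 log units; beyond the scatter), so this is the first change at this place that can be read alone, and it moves the read-out toward weaker inhibition. Compound 4 reads > 100000 nM in this assay, which is a limit and not a number. The true size of the step therefore stays unread: the limit of > 100000 nM in this assay, at which 1 of the 4 values shown sits.

The compounds shown leave open whether a plain butoxy chain or a cyclopropylmethoxy group in the same place, on the core of compound 2, would keep the inhibition of compound 2, and so whether the ring of the cyclopentyl matters or only the carbon it brings. They also cannot show whether the same change would act alike on the core of compound 3, since no pair shown tests that.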